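Thiourea in place of urea on two sulfonamide cores

The source may report more compounds than this note shows. Statements on the series, on what has been measured and on what is new or still open speak of the compounds shown alone.

Three compounds were tested in an ADME assay on HEK-293T cells (Homo sapiens) for cytotoxicity, read by CCK-8 assay, with a stated time of 48 h; on this read-out lower numbers stand for stronger inhibition and higher numbers for weaker inhibition. Compound 1, `O=C(NCCNS(=O)(=O)c1ccc(-c2ccccc2OCc2cccc(O)c2)s1)Nc1cc(Cl)cc(Cl)c1`, gives only a limit in this assay, > 20000 nM; the limit of > 20000 nM in this assay, at which 1 of the 3 values shown sits, marks that limit. Compound 2, `O=[N+]([O-])c1cccc(NC(=S)NCCNS(=O)(=O)c2ccc(-c3ccccc3OCc3cccc(O)c3)s2)c1`, differs from compound 1 in one place: a group of 12 heavy atoms (7 carbon, 2 nitrogen, 2 oxygen, 1 sulfur; one six-membered aromatic ring of carbon only) in place of a group of 11 heavy atoms (7 carbon, 1 nitrogen, 1 oxygen, 2 chlorine; one six-membered aromatic ring of carbon only), on an amine nitrogen. In this assay compound 2 gives 13800 nM, so that the change made an at least 1.4-fold lower number from compound 1 to compound 2 (0.16 log units; that floor lies within the scatter).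

Compound 3, `Cc1ccc(-c2ccsc2S(=O)(=O)NCCNC(=O)Nc2cc(Cl)cc(Cl)c2)c(Oc2ccc(O)c(O)c2)c1`, rests on another core; how its core differs from the core of compound 1 is not broken down here. In this assay compound 3 gives 6700 nM, the lowest of the two numbers, and its step to compound 2 lies beyond the scatter.

Compound 4, `Cc1ccc(-c2ccsc2S(=O)(=O)NCCNC(=S)Nc2cccc([N+](=O)[O-])c2)c(Oc2ccc(O)c(O)c2)c1`, is not yet measured. It differs from compound 3 by the same kind of change that leads from compound 1 to compound 2: a group of 12 heavy atoms (7 carbon, 2 nitrogen, 2 oxygen, 1 sulfur; one six-membered aromatic ring of carbon only) in place of a group of 11 heavy atoms (7 carbon, 1 nitrogen, 1 oxygen, 2 chlorine; one six-membered aromatic ring of carbon only), on an amine nitrogen. The place of the change is the same word for word in both cases, an amine nitrogen whose other neighbours are a saturated chain carbon. The earlier step is known only as a floor that lies within the scatter, so only a small and uncertain step is expected here. The expected step in this assay is a 1.5-fold lower number from compound 3 to compound 4 (0.17 log units; within the scatter). That expectation rests on the step of an at least 1.4-fold lower number from compound 1 to compound 2 (0.16 log units; that floor lies within the scatter). On this basis compound 4 is estimated at 4500 nM in this assay, with the number expected to fall between 1500 nM and 13000 nM.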

Compound 4, half-maximal inhibitory concentration: 7900 nM
Compound 4: middle estimate off by 1.8-fold (0.24 log units), on the low side; low and high end bracket the measured number.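

On the core shared by the later pair, the change gives a 1.2-fold higher number from compound 3 to compound 4 (0.07 log units; within the scatter) in this assay, a step that does not separate the two compounds. Set beside the step on the other core, the result reads: the same change on two cores in this assay, an at least 1.4-fold lower number (0.16 log units; that floor lies within the scatter) from compound 1 to compound 2 and a 1.2-fold higher number (0.07 log units; within the scatter) from compound 3 to compound 4; the limit leaves it open whether they differ

Compound 1 gives a limit of the assay, > 20000 nM, and not a number, so the earlier step is known only as a floor. Among the compounds shown here, the two cores therefore show no sign in this assay that the change has a large effect on the second core, but they do not show that it acts alike on both, and they give no size for the step on the core of compound 1.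

In both steps the carbonyl becomes a thiocarbonyl while the groups on the aromatic ring change as well, and the compounds shown do not separate these two parts of the change. They also leave open how the read-out in this assay would respond to an amine or a carboxylic acid on that ring, or to a longer chain in place of the saturated chain on the amine nitrogen.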